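From Carboxy to Carbamoyl at the Assay Limit

The source may hold more compounds than are shown below. What is called first, only, known or untested is meant among the compounds shown, and "the series" means these compounds.

Measured so far in an ADME assay on HEK-293T cells (Homo sapiens) for cytotoxicity, read by luminescence, with a stated time of 24 h; on this read-out lower numbers stand for higher toxicity in this test and higher numbers for lower toxicity in this test:
Compound 1 `COc1ccc(Cn2c(C(N)=O)cc3sccc32)cc1`: > 100000 nM (a limit)
Compound 2 `COc1ccc(Cn2c(C(=O)N3CCC(C(=O)O)CC3)cc3sccc32)cc1`: > 100000 nM (a limit)

Compound 2 yields no number in this assay: compound 2 reads > 100000 nM, which is a limit of the assay. Among the measured compounds shown here, it shares that position with the only other measured compound, as the record shows: the limit of > 100000 nM in this assay, at which 2 of the 2 values shown sit.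

Compound 3 `COc1ccc(Cn2c(C(=O)N3CCC(C(N)=O)CC3)cc3sccc32)cc1` differs from compound 2 in one place, with amino in place of hydroxy on a carbonyl carbon, so that carboxy becomes carbamoyl (amino in place of hydroxy on a carbonyl carbon). For the measured compounds named here, one measured step bears on this change: a step that the two limits leave unreadable from compound 1 to compound 2. It replaced amino on a carbonyl carbon with 4-carboxypiperidin-1-yl, and it offers no size to carry over. Compound 1, which also has amino on a carbonyl carbon, reads > 100000 nM, again a limit. With that value in view, no step beyond the usual scatter is expected in this assay, and no direction can be assigned. The expected step is a number no higher from compound 2 to compound 3 (the limit leaves the size open). For compound 3 the estimate is 100000 nM, with an expected range from 50000 nM to 200000 nM.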

Compound 3, half-maximal cytotoxic concentration: > 100000 nM
Compound 3 was reported as a limit (the forecaster's own chance of this, stated with the estimate: 85%); the middle value sits exactly at the limit.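

In this assay, among the compounds shown here, compound 3 reads > 100000 nM, which is a limit, so no step among compound 1, compound 2 and compound 3 can be read. All three stand at the same place: the limit of > 100000 nM in this assay, at which 3 of the 3 values shown sit.

The compounds shown leave open whether carboxy and carbamoyl on the 4-substituted piperidin-1-yl group differ at all in this read-out.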